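The source may hold more compounds than are shown below. What is called first, only, known or untested is meant among the compounds shown, and "the series" means these compounds.

Of the compounds shown here, two with a shared core have been measured in an assay for inhibition of 15-hydroxyprostaglandin dehydrogenase [NAD(+)] (Homo sapiens), read by fluorescence and spectrophotometry; a higher number here means a weaker inhibitor, a lower number a stronger inhibitor. Compound 1 `CC(C)OCCOc1ccc(/C=C2\SC(=O)NC2=O)c(Cl)c1` gives 1050 nM, while compound 2 `O=C1NC(=O)/C(=C/c2ccc(OC(=O)c3cccs3)c(Cl)c2)S1` gives 264 nM. Of these two numbers, compound 2 has the lower one, and the gap to compound 1 lies beyond the usual scatter of repeated measurements, so compound 2 counts as the stronger inhibitor of the pair.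

Compound 3 `O=C1NC(=O)/C(=C/c2ccc(OCC3CCC3)c(Cl)c2)S1` has not yet been measured. It differs from compound 2 in one place: cyclobutylmethyl in place of (thiophen-2-yl)carbonyl on an oxygen on an aromatic ring. The ether-type side chain of compound 1 goes with the weaker of the two measured values, and compound 3 likewise carries a hydrocarbon group on that oxygen rather than the carbonyl-linked ring of compound 2. The expectation for compound 3 is therefore a weakening, a step of a 3.0-fold higher number from compound 2 to compound 3 (0.48 log units; beyond the scatter), beyond the scatter but not large. The estimated value for compound 3 in this assay is 800 nM, with a range from 250 nM to 2500 nM.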

Compound 3, half-maximal inhibitory concentration: 9 nM
Compound 3: the middle estimate sits 89-fold (1.95 log units) above what was measured; measured number outside the range, below it.
By their numbers in this assay, from the lowest: compound 3; then compound 2; then compound 1.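

At this oxygen on an aromatic ring, the choice of group matters greatly in this assay: putting cyclobutylmethyl in place of (thiophen-2-yl)carbonyl gives a 29-fold lower number from compound 2 to compound 3 (1.47 log units; beyond the scatter), a large step beyond the scatter. The carbonyl-linked aromatic ring is therefore not needed for strong inhibition here, since the all-carbon cyclobutylmethyl group, which has no hydrogen-bond acceptors, carries the lower number. No measurement at hand says why the number falls.

This one change removes the carbonyl and the thiophene ring together, and the compounds shown cannot tell which of the two loss matters, or whether the gain comes from the cyclobutylmethyl group itself. From the compounds shown here alone, whether a cyclopentylmethyl group, a longer chain or an amine-bearing chain on the same oxygen would keep the number this low also remains open.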